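This account rests on a few compounds, and the source may have more. Where it says the series, first, only, none or still open, it means among the compounds named here.

Measured so far in an ADME assay on HeLa Rh cells (Homo sapiens) for cytotoxicity, read by microscopy; a lower number here means that less compound is tolerated, a higher number that more compound is tolerated:
compound 1, `COc1cc(CC(O)c2ccc(-c3ccc(C(F)(F)F)cc3)cc2)c([N+](=O)[O-])cc1OC`: 4100 nM
compound 2, `COc1cc(CC(O)c2ccc(-c3ccc(Br)cc3)cc2)c([N+](=O)[O-])cc1OC`: 4300 nM

Compound 2 and compound 1 differ only in the group on the outer aromatic ring, and the step of a 1.0-fold higher number from compound 1 to compound 2 (0.02 log units; within the scatter) shows that this exchange left the number where it was. Compound 2 therefore stands together with compound 1 within the scatter of this assay, with no order between them.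

Compound 3, `COc1cc(CC(O)c2ccc(-c3cccc(C#N)c3)cc2)c([N+](=O)[O-])cc1OC`, is not yet measured. Its change from compound 2 is 3-cyanophenyl in place of 4-bromophenyl on an aromatic carbon. Among the compounds with values here, the only measured step that bears on it, a 1.0-fold higher number from compound 1 to compound 2 (0.02 log units; within the scatter), exchanged one group on that same ring without a shift beyond the scatter; no measured step covers a 3-cyanophenyl. The step is therefore expected to be small, with no direction beyond the scatter, so that a 1.1-fold lower number from compound 2 to compound 3 (0.03 log units; within the scatter) is estimated. Compound 3 is expected to give about 4000 nM in this assay, within a range of 2000 nM to 8000 nM.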

Compound 3, half-maximal cytotoxic concentration: 5200 nM
Compound 3: the middle estimate sits 1.3-fold (0.11 log units) below what was measured, within the range that was stated.
By their numbers in this assay, from the lowest: compounds 1, 2 and 3 (each within the scatter of the next).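

In this assay, 3-cyanophenyl in place of 4-bromophenyl gave a 1.2-fold higher number from compound 2 to compound 3 (0.08 log units; within the scatter), and the same group in place of 4-(trifluoromethyl)phenyl gave a 1.3-fold higher number from compound 1 to compound 3 (0.10 log units; within the scatter). The earlier flatness at this place therefore holds beyond 4-bromophenyl and 4-(trifluoromethyl)phenyl: it extends to a 3-cyanophenyl, which brings a nitrile and a hydrogen-bond acceptor, and the three compounds stand within the scatter with no order among them. No measurement is at hand that would account for this flatness.

Open, going by these compounds, is whether 4-cyanophenyl would read the same, since the step to 3-cyanophenyl exchanged the group and its numbered place together. Also open, on these data alone, is whether an amine or a carboxylic acid on this ring, or a longer chain in place of the ring, would shift the number beyond the scatter.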